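Methyl for hydrogen on the ring nitrogen of compound 1

This account rests on a few compounds, and the source may have more. Where it says the series, first, only, none or still open, it means among the compounds named here.

Measured compounds:
compound 1 `Cc1ccc(S(=O)(=O)Nc2cc[nH]c(=O)n2)cc1` — > 100000 nM
compound 2 `Cn1cc(CO)c(N)nc1=O` — > 100000 nM
compound 3 `CSc1cc[nH]c(=O)n1` — > 100000 nM

In a functional assay on MIA PaCa-2 cells (Homo sapiens) for inhibition, read by MTT assay, with a stated time of 72 h (on this read-out lower numbers stand for stronger inhibition and higher numbers for weaker inhibition), compound 1 gives > 100000 nM, which is a limit of the assay and not a number. Compound 2 gives > 100000 nM, likewise a limit. Compound 3 gives > 100000 nM, also a limit. Compound 1 thus sits at the limit of > 100000 nM in this assay, at which 3 of the 3 values shown sit, and no numbered value is available among the three.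

Compound 4 `Cc1ccc(S(=O)(=O)Nc2ccn(C)c(=O)n2)cc1` differs from compound 1 by methyl in place of hydrogen on an aromatic nitrogen. Among the measured compounds shown here, no measured pair shows the effect of this change, so nothing sets its size or direction. The expected step of a number no higher from compound 1 to compound 4 (the limit leaves the size open) is none beyond the scatter. Compound 4 is therefore estimated at 100000 nM, between 30000 nM and 300000 nM, and most probably reported again only as a limit.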

Compound 4, half-maximal inhibitory concentration: > 100000 nM
Compound 4 gave a limit, no number; the forecaster's own chance of this, stated with the estimate: 85%; the middle value sits exactly at the limit.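

No step can be read between compound 1 and compound 4, as each value is a limit and not a number: the limit of > 100000 nM in this assay, at which 4 of the 4 values shown sit.

The compounds shown leave open whether any change to the core of compound 1 gives a numbered value in this assay.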